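Stereoisomers of one structure: expectation for compound 4

A few compounds are considered here, and "the series" means these few. Any claim that something is new, unique, unknown or untested is made for them only; others in the source may bear on it.

Values in a functional assay on HT529 cells (Homo sapiens) for cytotoxicity; a lower number here means a stronger inhibitor, a higher number a weaker inhibitor:
- compound 1 `CCCCCCCCCCCCCC[C@H]1N[C@H](CO)[C@H]1O` gives 1.23 ug/mL
- compound 2 `CCCCCCCCCCCCCC[C@@H]1N[C@H](CO)[C@H]1O` gives 0.79 ug/mL
- compound 3 `CCCCCCCCCCCCCC[C@H]1N[C@@H](CO)[C@@H]1O` gives 0.17 ug/mL

Compound 3 has the lowest number of the three, and its steps to both others lie beyond the scatter. Compound 4 `CCCCCCCCCCCCCC[C@@H]1N[C@H](CO)[C@@H]1O` follows from compound 3 through (the two compounds have the same atoms and bonds and differ only in configuration as drawn: 2 of 3 stereo elements differ; a stereocentre at a saturated ring carbon is drawn R in compound 3 and S in compound 4; a stereocentre at a saturated ring carbon is drawn S in compound 3 and R in compound 4). Two measured steps, both modest, also change only configuration and end at compound 3: a 7.2-fold lower number from compound 1 to compound 3 (0.86 log units; beyond the scatter) and a 4.6-fold lower number from compound 2 to compound 3 (0.67 log units; beyond the scatter). By contrast, a 1.6-fold lower number from compound 1 to compound 2 (0.19 log units; within the scatter) stays within the scatter. Each configuration measured other than that of compound 3 gives a higher number, so a rise of similar or somewhat smaller size is expected. The expected step is a 3.5-fold higher number from compound 3 to compound 4 (0.55 log units; beyond the scatter). For compound 4 the estimate is 0.6 ug/mL, with an expected range of 0.2 ug/mL to 1.6 ug/mL.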

Compound 4, half-maximal inhibitory concentration: > 2 ug/mL
Compound 4 was reported as a limit (the forecaster's own chance of this, stated with the estimate: 3%); middle value at least 3.3-fold (0.52 log units) from the limit.
By their numbers in this assay, from the lowest: compound 3; then compounds 2 and 1 (each within the scatter of the next). At a limit, above all of these: compound 4.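

Compound 4 is reported in this assay only as a limit, > 2 ug/mL. Configuration alone now carries a far wider span, with an at least 11-fold higher number from compound 3 to compound 4 (1.07 log units; beyond the scatter), and one inverted stereocentre gives an at least 2.5-fold higher number from compound 2 to compound 4 (0.40 log units; beyond the scatter), whereas the single inversion in a 1.6-fold lower number from compound 1 to compound 2 (0.19 log units; within the scatter) left the numbers within the scatter. Single inversions therefore differ in their effect in this set, while an at least 1.6-fold higher number from compound 1 to compound 4 (0.21 log units; that floor lies within the scatter) cannot be read as a real separation.

As far as these compounds go, the true value of compound 4 remains open. Also open, from the compounds shown here alone, is whether this order of configurations would hold with a shorter chain, or with an amine or a carboxylic acid on the shared core.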